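The source may hold more compounds than are shown below. What is called first, only, known or untested is meant among the compounds shown, and "the series" means these compounds.

In a functional assay on Huh-7 cells (Homo sapiens) for inhibition, read by MTT assay, with a stated time of 48 h (on this read-out higher numbers stand for weaker inhibition and lower numbers for stronger inhibition), compound 3 `COc1ccc2c(=O)c(/C=C/C(=O)NCc3ccc(F)cc3)coc2c1` gives 21000 nM and compound 1 `COc1ccc2c(=O)c(/C=C/C(=O)Nc3cccc(C)c3)coc2c1` gives 15500 nM in the same range, with a 1.4-fold higher number from compound 1 to compound 3 (0.13 log units; within the scatter) on 4-fluorobenzyl replacing 3-methylphenyl on the amide-type nitrogen. Compound 2 `COc1ccc2c(=O)c(/C=C/C(=O)Nc3cccc(Cl)c3)coc2c1` gives > 100000 nM as a limit of the assay, not a number. Compound 4 `COc1ccc2c(=O)c(/C=C/C(=O)NCc3ccc(C)cc3)coc2c1` differs from compound 3 by methyl in place of fluoro on an aromatic carbon with methyl in place of fluoro on an aromatic carbon. Within the data shown here, no measured step makes this exact exchange. The nearest, chloro in place of methyl, is an at least 6.4-fold higher number from compound 1 to compound 2 (0.80 log units; beyond the scatter) in another setting, while the step of an at least 4.7-fold lower number from compound 2 to compound 3 (0.67 log units; beyond the scatter) replaces the whole nitrogen substituent. The expected step in this assay is a 1.1-fold lower number from compound 3 to compound 4 (0.04 log units; within the scatter) and is estimated to stay within the scatter. Compound 4 is expected at 19000 nM with an estimated range from 7000 nM to 55000 nM in this assay.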

Compound 4, half-maximal inhibitory concentration: 14300 nM
Compound 4: middle estimate off by 1.3-fold (0.12 log units), on the high side, within the range that was stated.
By their numbers in this assay, from the lowest: compounds 4, 1 and 3 (each within the scatter of the next). At a limit, above all of these: compound 2.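

In this assay, the change from 4-fluorobenzyl to 4-methylbenzyl stays within the scatter, a 1.5-fold lower number from compound 3 to compound 4 (0.17 log units; within the scatter), so at this position, para to a large group, the two groups cannot be told apart. Exchanging the whole nitrogen substituent for 4-methylbenzyl likewise stays within the scatter, a 1.1-fold lower number from compound 1 to compound 4 (0.03 log units; within the scatter). Compound 2 has a limit and not a number, and the step to the new compound, an at least 6.9-fold lower number from compound 2 to compound 4 (0.84 log units; beyond the scatter), lies beyond the scatter. On these data alone, whether an amine or a carboxylic acid at this position would move the number beyond the scatter remains open.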